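Compound 1 and compound 3 in a cytotoxicity assay

This account rests on a few compounds, and the source may have more. Where it says the series, first, only, none or still open, it means among the compounds named here.

Measured compounds:
- compound 1 `[N-]=[N+]=NCCCc1ccc(-c2ccc(-c3ccc(-c4cccs4)s3)s2)s1`: > 100000 nM
- compound 2 `[N-]=[N+]=NCCCCc1ccc(-c2ccc(-c3ccc(-c4cccs4)s3)s2)s1`: "not determined" (no result reported)

In an ADME assay on MDCK cells (Canis lupus familiaris) for cytotoxicity, read by MTT assay, with a stated time of 2 days (on this read-out higher numbers stand for lower toxicity in this test and lower numbers for higher toxicity in this test), compound 1 reaches only a limit, > 100000 nM, not a number. For compound 2 the read-out in this assay is "not determined" (no result reported). Compound 1 therefore stands at the limit of > 100000 nM in this assay, at which 1 of the 2 values shown sits, and no single number is known for any compound here.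

Compound 3 `[N-]=[N+]=NCCCc1ccc(-c2ccc(-c3cccs3)s2)s1` is the compound still to be measured. It differs from compound 1 in one place: hydrogen in place of thiophen-2-yl on an aromatic carbon. For the measured compounds named here, as no step between two measured compounds is known, the expectation rests on compound 1 alone. In this assay compound 3 is expected to give 100000 nM, within 50000 nM to 200000 nM. This means an expected step of a number no higher from compound 1 to compound 3 (the limit leaves the size open), that is, no change beyond the scatter, with the reading likely to end again at a limit.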

Compound 3, half-maximal cytotoxic concentration: > 200000 nM
Compound 3 was reported as a limit (the forecaster's own chance of this, stated with the estimate: 75%); middle value at least 2.0-fold (0.30 log units) from the limit.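

Compound 1 and compound 3 each end at a limit rather than a number in this assay, so the step between them cannot be read. The compounds shown leave open whether hydrogen in place of thiophen-2-yl changes the reading at all, and in which direction.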